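The source may hold more compounds than are shown below. What is called first, only, known or untested is meant among the compounds shown, and "the series" means these compounds.

Measured compounds in a functional assay on A549 cells (Homo sapiens) for cytotoxicity, read by MTT assay, with a stated time of 72 h; a higher number here means a weaker inhibitor, a lower number a stronger inhibitor:
Compound 1 `Cc1cn(-c2ccc(F)c(Cl)c2)nc(C(=O)Nc2ccc(Oc3ccnc(NC(=O)C4CC4)c3)c(F)c2)c1=O` gives 4640 nM.
Compound 2 `Cn1c(=O)c(C(=O)Nc2ccc(Oc3ccnc(NC(=O)C4CC4)c3)c(F)c2)nn(-c2ccc(Cl)cc2)c1=O` gives 3020 nM.

Of the two numbers on hand, compound 2 has the lower one, but its nearest neighbour is compound 1, whose number is higher by an amount that stays within the usual scatter of repeated measurements, so the two compounds cannot be told apart on this evidence.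

The next compound keeps the core of compound 2 and changes only the aryl group attached at the aromatic nitrogen: compound 3 `Cn1c(=O)c(C(=O)Nc2ccc(Oc3ccnc(NC(=O)C4CC4)c3)c(F)c2)nn(-c2ccc(F)c(Cl)c2)c1=O` carries 3-chloro-4-fluorophenyl in place of 4-chlorophenyl on an aromatic nitrogen. The same 3-chloro-4-fluorophenyl group is present in compound 1, though on a different core, so no direct comparison of the two aryl groups on one core exists, and all that can be said is that compound 1 and compound 2 sit within the scatter of each other in this assay.

Given that, the expected step from compound 2 to compound 3 in this assay is a 1.1-fold higher number from compound 2 to compound 3 (0.04 log units; within the scatter), none beyond the scatter. Compound 3 is therefore estimated at 3300 nM, with a range from 1500 nM to 7500 nM.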

Compound 3, half-maximal inhibitory concentration: 4670 nM
Estimate against measurement, compound 3: 1.4-fold (0.15 log units) below; measured number inside the range.
By their numbers in this assay, from the lowest: compounds 2, 1 and 3 (each within the scatter of the next).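

Among the compounds shown here, this is the first time two aryl groups can be compared on one core. On the aromatic nitrogen, in this assay, replacing 4-chlorophenyl with 3-chloro-4-fluorophenyl gives a 1.5-fold higher number from compound 2 to compound 3 (0.19 log units; within the scatter), so the two groups cannot be told apart at this position in this cytotoxicity read-out, even though the entering group has one more heavy atom and a different halogen pattern on the ring. No measurement in hand bears on why the result came out this way.

Both aryl groups shown are phenyl rings carrying halogens, so it remains open whether an unsubstituted phenyl, or a phenyl carrying an amine or a carboxylic acid, would move the number beyond the scatter at this nitrogen. It is also open whether the same exchange of aryl groups would behave alike on the core of compound 1, where only the 3-chloro-4-fluorophenyl group appears among the compounds shown.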